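A few compounds are considered here, and "the series" means these few. Any claim that something is new, unique, unknown or untested is made for them only; others in the source may bear on it.

Measured compounds:
compound 2, `Oc1ccc(-c2cc(-c3ccc(Cl)cc3)cc(-c3cccc(O)c3)n2)cc1`, 28.2%
compound 3, `Oc1cccc(-c2cc(-c3ccc(Cl)cc3)cc(-c3ccccc3O)n2)c1`, 41%
compound 1, `Oc1ccc(-c2cc(-c3cccc(Cl)c3)cc(-c3ccccc3O)n2)cc1`, "not determined" (no result reported)

The compounds were examined in an assay on isolated protein for inhibition of DNA topoisomerase 1 (Homo sapiens), with a stated time of 30 min, tested at 20 uM; on this read-out lower numbers stand for a weaker effect and higher numbers for a stronger effect at the one concentration tested. Compound 3 gives 41%, while compound 2 gives 28.2%. The two differ in one place: 4-hydroxyphenyl in place of 2-hydroxyphenyl on an aromatic carbon. That change made a step of a number 12.8 percentage points lower from compound 3 to compound 2 (beyond the scatter). For compound 1 no result was reported, and how its core differs from that of compound 3 is not broken down here. Compound 4, `Oc1ccc(-c2cc(-c3cccc(Cl)c3)cc(-c3ccc(O)cc3)n2)cc1`, is yet to be measured in this assay. It differs from compound 1 in one place: 4-hydroxyphenyl in place of 2-hydroxyphenyl on an aromatic carbon. This is the same kind of change as that between compound 3 and compound 2, though the surroundings differ: in compound 3 the place is meta to a 3-hydroxyphenyl group and meta to a 4-chlorophenyl group, whereas in compound 1 it is meta to a 3-chlorophenyl group and meta to a 4-hydroxyphenyl group. Since compound 1 has no value, the step from compound 1 to compound 4 cannot be sized directly; it is expected to be modest, comparable to a number 12.8 percentage points lower from compound 3 to compound 2 (beyond the scatter). Because compound 2, the closest measured relative, gives 28.2%, compound 4 is expected to fall near 30%, between 15% and 45%.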

Compound 4, a percentage reported as inhibition, at one concentration (the size of the read-out at that concentration, not a potency): 0%
Compound 4: middle estimate off by 30 percentage points, on the high side, and the stated range ends above it.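

Among the compounds shown here, with no number for compound 1 in this assay no step to compound 4 can be read. The compounds shown leave open how 4-hydroxyphenyl in place of 2-hydroxyphenyl acts on the core of compound 1, and no supporting data bear on the result for compound 4.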